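Swapping Cyclohexyl for Benzyl on the Shared Core

The source may report more compounds than this note shows. Statements on the series, on what has been measured and on what is new or still open speak of the compounds shown alone.

Compound 1 `O=Cc1ccc(-c2cn3ccnc3c(-c3ccc4ncn(C5CCCCC5)c4c3)n2)cc1`: 46.7%
Compound 2 `c1cn2cc(-c3ccsc3)nc(-c3ccc4ncn(C5CCCCC5)c4c3)c2n1`: 6.35%
Compound 3 `COc1ccccc1-c1cn2ccnc2c(-c2ccc3ncn(C4CCCCC4)c3c2)n1`: 12.3%

In a functional assay on 786-0 cells (Homo sapiens) for inhibition, read by sulforhodamine B assay, with a stated time of 48 h, tested at 10 uM (on this read-out lower numbers stand for less inhibition and higher numbers for more inhibition at the one concentration tested (going by the name of the read-out)), compound 1 gives 46.7%, the highest of the three numbers. The other two fall well short of it: a number 40.4 percentage points lower from compound 1 to compound 2 (beyond the scatter) and a number 34.4 percentage points lower from compound 1 to compound 3 (beyond the scatter), both steps beyond the scatter, while compound 2 and compound 3 sit within the scatter of each other, so no order can be drawn between them.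

Compound 4 `O=Cc1ccc(-c2cn3ccnc3c(-c3ccc4ncn(Cc5ccccc5)c4c3)n2)cc1` keeps the core and the 4-formylphenyl of compound 1 and differs in one place: benzyl in place of cyclohexyl on an aromatic nitrogen. None of the three measured steps touches this position; all of them exchange the group on the aromatic carbon and leave the cyclohexyl untouched. Going by the values given here, there is therefore no measured step that bears directly on this change, and the expectation can only rest on the value of compound 1 in this assay.

With no guidance on the size or direction of the change, compound 4 is expected to stay near compound 1, at an estimated 40%, within a range from 15% to 65%. The expected step is a number 6.7 percentage points lower from compound 1 to compound 4 (within the scatter), not beyond the scatter.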

Compound 4, a percentage reported as inhibition, at one concentration (the size of the read-out at that concentration, not a potency): 46.7%
The estimate for compound 4 lay 6.7 percentage points below the measured number, and the stated range covers the measured number.
By their numbers in this assay, from the lowest: compounds 2 and 3 (each within the scatter of the next); then compounds 1 and 4 (each within the scatter of the next).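

Going by these compounds alone, the earlier steps all changed the group on the aromatic carbon, and two of them were large; this is the first reading at the aromatic nitrogen of the five-membered ring, and in this assay it gives no change at the digits printed from compound 1 to compound 4 (within the scatter). With the 4-formylphenyl in place, then, the six-membered ring of carbon only can go from non-aromatic cyclohexyl to the aromatic ring of benzyl with no change beyond the scatter at the one concentration tested. The data at hand offer no explanation for this result.

Among the compounds shown, benzyl appears only with the 4-formylphenyl, so it remains open whether the same would hold with the thiophen-3-yl of compound 2 or the 2-methoxyphenyl of compound 3. Also open, as far as these compounds go, is how a methyl, an aminoethyl chain or a carboxylic acid on this nitrogen would read.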